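The compounds below may be only part of what the source reports. "The series", "measured", "known", "first", "only" and "open" are said of these compounds alone.

Compound 1 `CCCCCCCCCCCCCC(=O)Nc1nnc(S[C@@H]2O[C@H](COC(C)=O)[C@H](OC(C)=O)[C@H](OC(C)=O)[C@H]2OC(C)=O)s1` belongs to a small set of acylated thiadiazole thioglycosides examined for cytotoxicity in a functional assay on MDA-MB-231 cells (Homo sapiens) for cytotoxicity, read by MTT assay, with a stated time of 24 h (on this read-out higher numbers stand for weaker inhibition and lower numbers for stronger inhibition), where compound 1 gives 26200 nM. Among the three compounds with a number, compound 1 stands second highest; its nearest neighbour is compound 2 `CCCCCCCC/C=C\CCCCCCCC(=O)Nc1nnc(S[C@@H]2O[C@H](COC(C)=O)[C@H](OC(C)=O)[C@H](OC(C)=O)[C@H]2OC(C)=O)s1`, which in this assay gives 23600 nM, and its furthest is compound 3 `CCCCCCCCCCCC(=O)Nc1nnc(S[C@@H]2O[C@H](CO)[C@H](O)[C@H](O)[C@H]2O)s1`, which gives 32000 nM. The unmeasured compound 4 `CCCCCCCC/C=C\CCCCCCCCCCCC(=O)Nc1nnc(S[C@@H]2O[C@H](COC(C)=O)[C@H](OC(C)=O)[C@H](OC(C)=O)[C@H]2OC(C)=O)s1` differs from compound 1 in one place: dec-1-en-1-yl in place of ethyl on a saturated chain carbon, ten or more bonds along the chain from a carbonyl carbon. Among the compounds with values here, the single measured step that bears on this change is the move a 1.1-fold lower number from compound 1 to compound 2 (0.05 log units; within the scatter), where a double bond was brought into a longer chain without a change beyond the scatter. Within the data shown here, compound 3 carries a shorter chain and free hydroxyls, so it offers no step to compound 1 that can be read as one change. On that basis the step from compound 1 to compound 4 is expected to be a 1.1-fold lower number from compound 1 to compound 4 (0.04 log units; within the scatter), again within the scatter. Compound 4 is therefore estimated to give 24000 nM in this assay, with a range from 12000 nM to 48000 nM.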

Compound 4, half-maximal inhibitory concentration: 25300 nM
Compound 4: middle estimate off by 1.1-fold (0.02 log units), on the low side; measured number inside the range.
By their numbers in this assay, from the lowest: compounds 2, 4, 1 and 3 (each within the scatter of the next).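

In this assay, the step of a 1.0-fold lower number from compound 1 to compound 4 (0.02 log units; within the scatter) stays within the scatter, so putting dec-1-en-1-yl in place of ethyl, with 10 heavy atoms entering and 2 leaving, leaves the read-out unmoved on a saturated chain carbon. The earlier step of a 1.1-fold lower number from compound 1 to compound 2 (0.05 log units; within the scatter) showed the same absence of a change beyond the scatter only for dec-1-en-1-yl in place of hexyl, seven bonds along the chain, so among these compounds it now holds at two places on the chain. No measurement shown here offers an explanation for this insensitivity.

As far as these compounds go, whether an amine or a carboxylic acid at this place, rather than another hydrocarbon group, would also leave the number within the scatter stays open. So does whether the same chain change would read alike on a core with free hydroxyls in place of the acetates.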